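This account rests on a few compounds, and the source may have more. Where it says the series, first, only, none or still open, it means among the compounds named here.

The series shares a core seen in compound 1 `O=C1S/C(=C\c2ccc(O)cc2)C(=O)N1Cc1ccccc1` and compound 2 `Cc1c(C)c2c(c(C)c1OC(=O)OC(C)(C)C)CCC(C)(CN1C(=O)S/C(=C\c3ccc(O)cc3)C1=O)O2`. In an ADME assay on cells (Hepatocyte, Homo sapiens) for cytotoxicity, read by MTT assay, with a stated time of 90 min, tested at 200 uM (a higher number here means a weaker effect of the compound at the concentration tested, a lower number a stronger effect), compound 1 gives 18%, and compound 2 gives 37.8%. Compound 1 stands lowest of the two numbers; the nearest, compound 2, lies higher by a gap beyond the usual scatter. Within the data shown here, no pair of measured compounds differs in only one place, so the size of a single structural change cannot be read off the measured values.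

Compound 3 `O=C1S/C(=C\c2ccc(O)cc2)C(=O)N1C/C=C/c1ccccc1` has not been measured in this assay. It differs from compound 1 in one place: 2-phenylethenyl in place of phenyl on a saturated chain carbon bound to an amide-type nitrogen in a ring. The change brings in one double bond outside aromatic rings and keeps the single six-membered aromatic ring of carbon only, with no hydrogen-bond donors or acceptors gained or lost. Among the measured compounds shown here, with no measured step of this kind at hand, compound 3 is expected to give about 21% in this assay, within 8% to 36%. The step this estimate means, a number 3 percentage points higher from compound 1 to compound 3 (within the scatter), is expected to be small, not beyond the scatter in either direction.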

Compound 3, a percentage reported as activity, at one concentration (the size of the read-out at that concentration, not a potency): 62.7%
Compound 3: middle estimate off by 41.7 percentage points, on the low side, outside the stated range (above it).
By their numbers in this assay, from the lowest: compound 1; then compound 2; then compound 3.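

Among these compounds, at the place on a saturated chain carbon bound to an amide-type nitrogen in a ring, the exchange of phenyl for 2-phenylethenyl gives the only single-place step so far in this assay, with a number 44.7 percentage points higher from compound 1 to compound 3 (beyond the scatter) and a large size. This position therefore responds strongly to the change, and the higher number means a weaker effect of compound 3 than of compound 1 at the concentration tested. The single six-membered aromatic ring of carbon only stays in place and the hydrogen-bond donor and acceptor counts stay the same, while one double bond outside aromatic rings enters, and nothing at hand bears on why the number moves this far.

What the compounds shown leave open is whether the double bond or the longer link to the aromatic ring goes with this step, which a saturated 3-phenylpropyl group at the same place could separate. Also open, as far as these compounds go, is how far the step carries over to other groups at this position, such as a longer unsaturated chain, an amine or a carboxylic acid.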